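Chloro-to-fluoro swap on the benzyl group, compound 4

The compounds below may be only part of what the source reports. "The series", "measured", "known", "first", "only" and "open" are said of these compounds alone.

Three members of the series have numbers in an assay on Cerebral cortex for displacement of a labelled ligand from adenosine receptor A1 (Bos taurus); on this read-out lower numbers stand for stronger inhibition and higher numbers for weaker inhibition. Compound 1 `CNc1nc(-c2ccccc2)nc2c1nnn2Cc1ccccc1F` gives 25 nM in this assay. Compound 2 `Fc1ccccc1Cn1nnc2c(NC3CC3)nc(-c3ccccc3)nc21` gives 15 nM in this assay. Compound 3 `Clc1ccccc1Cn1nnc2c(NC3CCCCC3)nc(-c3ccccc3)nc21` gives 34 nM in this assay. Compound 3 therefore holds the highest of the three numbers; its gap to compound 1 is within the scatter, while its gap to compound 2 lies beyond it. For the measured compounds named here, the only step between neighbours that differ in one place, a 1.7-fold lower number from compound 1 to compound 2 (0.22 log units; within the scatter), concerns cyclopropyl in place of methyl on a nitrogen on an aromatic ring and does not touch the halogen.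

Compound 4 `Fc1ccccc1Cn1nnc2c(NC3CCCCC3)nc(-c3ccccc3)nc21` differs from compound 3 by fluoro in place of chloro on an aromatic carbon, on an aromatic carbon of a six-membered aromatic ring of carbon only, ortho to a large group; read one bond further out, 2-chlorobenzyl becomes 2-fluorobenzyl. No measured pair in the series isolates this exchange, so no direction can be drawn from the shown steps, and a step no larger than the scatter is expected. The expected step in this assay is a 1.4-fold lower number from compound 3 to compound 4 (0.13 log units; within the scatter). Compound 4 is therefore estimated at 25 nM in this assay, with a range from 10 nM to 65 nM.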

Compound 4, inhibition constant: 1.15 nM
Compound 4: middle estimate off by 22-fold (1.34 log units), on the high side, outside the stated range (below it).
By their numbers in this assay, from the lowest: compound 4; then compounds 2, 1 and 3 (each within the scatter of the next, the first and the last beyond it).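

Working notes on the benzyl halogen: in this assay, 2-fluorobenzyl in place of 2-chlorobenzyl, an exchange of one heavy atom on an aromatic carbon, ortho to a large group, gives a large change (a 30-fold lower number from compound 3 to compound 4 (1.47 log units; beyond the scatter)), so this position is sensitive to the identity of the halogen when cyclohexyl sits on the nitrogen. With 2-fluorobenzyl held constant, the nitrogen substituent also proves to matter, which the earlier step from methyl to cyclopropyl, within the scatter, did not show: cyclohexyl gives large steps from both smaller groups (a 13-fold lower number from compound 2 to compound 4 (1.12 log units; beyond the scatter) and a 22-fold lower number from compound 1 to compound 4 (1.34 log units; beyond the scatter)), while the cyclohexyl compound 3, with chloro, stays at 34 nM in this assay. Nothing in the data shown gives a reason for the size of these steps.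

Still open, from the compounds shown here alone, is whether the exchange of chloro for fluoro has the same size with methyl or cyclopropyl on the nitrogen, and whether bromo, methoxy or an unsubstituted benzyl would follow either halogen at this position. The compounds shown also leave open how cyclopentyl or a longer chain such as n-butyl on the nitrogen would compare with cyclohexyl.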